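Losing a methyl from compound 1

The source may hold more compounds than are shown below. What is called first, only, known or untested is meant among the compounds shown, and "the series" means these compounds.

In a functional assay on HCT-116 cells (Homo sapiens) for inhibition (a higher number here means a weaker inhibitor of growth, a lower number a stronger inhibitor of growth), compound 1 (`Cc1n[nH]c(-c2cc(Cl)c(O)cc2O)c1-c1ccc(OCCCC#N)cc1`) gives 3600 nM while compound 2 (`N#CCCCOc1ccccc1-c1cn[nH]c1-c1cc(Cl)c(O)cc1O`) gives 31000 nM in the same test. Compound 1 thus holds the lower of the two numbers, and the gap between them lies beyond the scatter. Compound 3 (`N#CCCCOc1ccc(-c2cn[nH]c2-c2cc(Cl)c(O)cc2O)cc1`) departs from compound 1 in a single place, with hydrogen in place of methyl on an aromatic carbon. For the measured compounds named here, no pair of measured compounds isolates this change, so any forecast for this assay remains uncertain. A small step towards a higher number, meaning a somewhat weaker inhibitor of growth, is expected, though not one beyond the scatter: the expected step is a 1.7-fold higher number from compound 1 to compound 3 (0.22 log units; within the scatter) on this estimate. For compound 3 the estimated value is 6000 nM with an expected range from 2500 nM to 14000 nM in all.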

Compound 3, concentration for 50% growth inhibition: 6800 nM
For compound 3 the middle estimate is 1.1-fold (0.05 log units) below the measured one, within the range that was stated.
By their numbers in this assay, from the lowest: compounds 1 and 3 (each within the scatter of the next); then compound 2.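

In this assay, hydrogen in place of methyl on the aromatic carbon next to the ring nitrogen gives a 1.9-fold higher number from compound 1 to compound 3 (0.28 log units; within the scatter) and so leaves the two compounds indistinguishable in this test. This is the only pair shown that isolates this position, and it indicates that the methyl is not required for growth inhibition of this order in the core of compound 1. No available evidence bears on the reason for this result.

On these data alone, whether a larger or differently charged group on this carbon, such as an ethyl, an amine or a carboxylic acid, would produce a step beyond the scatter remains open. So does whether hydrogen and methyl would stay this close with a longer chain in place of the nitrile-bearing side chain.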